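Moving a hydroxyl group on an isoquinoline-type antiproliferative

The source may hold more compounds than are shown below. What is called first, only, known or untested is meant among the compounds shown, and "the series" means these compounds.

Compound 2 `COc1cc(OC)cc(-c2cc3ccccc3c(-c3cccc(O)c3)n2)c1` gives 760 nM in a functional assay on T47D cells (Homo sapiens) for cytotoxicity, read by CCK-8 assay and cell counting, with a stated time of 72 h (a lower number here means a stronger inhibitor, a higher number a weaker inhibitor), the lowest of the two numbers available; compound 1 `COc1ccc(-c2cc3ccccc3c(-c3ccc(O)cc3)n2)cc1` gives 1220 nM in this assay, and the gap between the two lies within the scatter. Compound 3 `COc1cc(OC)cc(-c2cc3ccccc3c(-c3ccc(O)cc3)n2)c1` differs from compound 2 only in that (4-hydroxyphenyl in place of 3-hydroxyphenyl on an aromatic carbon). Among the compounds with values here, no measured pair isolates this change, so nothing beyond the scatter is expected in this assay, in either direction. For compound 3 the estimated value in this assay is 900 nM, with a range from 350 nM to 2500 nM, which means an expected step of a 1.2-fold higher number from compound 2 to compound 3 (0.07 log units; within the scatter).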

Compound 3, half-maximal inhibitory concentration: 780 nM
For compound 3 the middle estimate is 1.2-fold (0.06 log units) above the measured one; low and high end bracket the measured number.
By their numbers in this assay, from the lowest: compounds 2, 3 and 1 (each within the scatter of the next).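

In this assay, within the data shown here, the swap of 3-hydroxyphenyl for 4-hydroxyphenyl on the aromatic carbon next to the ring nitrogen brings a 1.0-fold higher number from compound 2 to compound 3 (0.01 log units; within the scatter) and gives the first direct reading of this change. On this core, the two placements of the hydroxyl cannot be told apart. Nothing available explains this result. Still open, on these data alone, is whether another group on that phenyl ring, such as an amine or a carboxylic acid, would leave the number equally unmoved. As far as these compounds go, it is also open whether the same swap would read alike on other cores.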